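The compounds below may be only part of what the source reports. "The series", "measured", "known", "first", "only" and "open" are said of these compounds alone.

Compound 3, `CC1CCN(c2c(S(=O)(=O)c3cccc(C#N)c3)cnc3cc(Cl)ccc23)CC1`, gives 94% in an assay on isolated protein for displacement of a labelled ligand from metabotropic glutamate receptor 5 (Homo sapiens), with a stated time of 60 min, tested at 1 uM; a lower number here means less inhibition, a higher number more inhibition at the concentration tested (going by the name of the read-out). Among the three compounds measured it gives the highest number, but only narrowly: compound 1, `CC1CCN(c2c(S(=O)(=O)c3cc(Cl)cc(Cl)c3)cnc3cc(Cl)ccc23)CC1`, gives 93%, and compound 2, `Cc1ccc(S(=O)(=O)c2cnc3cc(Cl)ccc3c2N2CCC(C)CC2)cc1C`, gives 86%, so both a number 1 percentage points higher from compound 1 to compound 3 (within the scatter) and a number 8 percentage points higher from compound 2 to compound 3 (within the scatter) lie within the scatter. Compound 4, `COc1ccc(S(=O)(=O)c2cnc3cc(Cl)ccc3c2N2CCC(C)CC2)cc1OC`, differs from compound 3 in one place: 3,4-dimethoxyphenyl in place of 3-cyanophenyl on a sulfonyl sulfur.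

Every step seen so far swaps the aryl group on the sulfonyl sulfur, and none of them moved the read-out beyond the scatter: a dichlorinated ring, a dimethylated ring and a cyano-bearing ring all gave much the same inhibition, with a number 7 percentage points lower from compound 1 to compound 2 (within the scatter) the largest of the three. On this evidence a dimethoxylated ring at the same place is expected to behave alike, so the step of a number 6 percentage points lower from compound 3 to compound 4 (within the scatter) is estimated to stay within the scatter. Compound 4 is therefore expected to give about 88%, with a likely range from 74% to 97%.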

Compound 4, a percentage reported as inhibition, at one concentration (the size of the read-out at that concentration, not a potency): 93%
Compound 4: middle estimate off by 5 percentage points, on the low side; low and high end bracket the measured number.
By their numbers in this assay, from the lowest: compounds 2, 1, 4 and 3 (each within the scatter of the next).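

With 3,4-dimethoxyphenyl on the sulfonyl sulfur, a ring bearing oxygen atoms joins the series, and in this assay the result is a number 1 percentage points lower from compound 3 to compound 4 (within the scatter) and a number 7 percentage points higher from compound 2 to compound 4 (within the scatter) and no change at the digits printed from compound 1 to compound 4 (within the scatter). The four aryl groups shown at this place therefore cannot be told apart by this read-out, even though their ring substituents include chloro, methyl, nitrile and methoxy groups. Nothing available gives a measured reason for this sameness.

On these data alone, it remains open whether a ring bearing an amine or a carboxylic acid, or a plain methyl group in place of the aryl ring, would keep this level of inhibition on the sulfonyl sulfur. As far as these compounds go, whether the four compounds differ in potency also remains open, as a reading at one concentration does not give a potency.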